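This account rests on a few compounds, and the source may have more. Where it says the series, first, only, none or still open, it means among the compounds named here.

Measured in a functional assay on HCT-116 cells (Homo sapiens) for antiproliferative activity, read by MTT assay, with a stated time of 72 h; on this read-out higher numbers stand for weaker inhibition and lower numbers for stronger inhibition:
Compound 1 `Cc1ccc(NC(=O)CCc2cccc3c2B(O)OC3)cc1`: 4500 nM
Compound 2 `CC(C)(C)OC(=O)Nc1ccc(NC(=O)CCc2cccc3c2B(O)OC3)cc1`: 24000 nM

Of these two numbers, the higher belongs to compound 2, at 24000 nM, which makes it the weaker inhibitor of the pair. Compound 3 `CC(C)(C)OC(=O)NCc1ccc(NC(=O)CCc2cccc3c2B(O)OC3)cc1` has not yet been measured. Its difference from compound 2 is ((tert-butoxycarbonyl)amino)methyl in place of (tert-butoxycarbonyl)amino on an aromatic carbon. For the measured compounds named here, only one measured step bears on this change, a 5.3-fold higher number from compound 1 to compound 2 (0.73 log units; beyond the scatter), and it was modest. Going by the values given here, that step swapped methyl for (tert-butoxycarbonyl)amino, and no measured compound carries the entering group, so the evidence is indirect. A smaller step than that one is therefore expected in this assay, most likely none beyond the scatter, with neither direction favoured. The expected step is a 1.2-fold lower number from compound 2 to compound 3 (0.08 log units; within the scatter). Compound 3 is estimated at 20000 nM, with an expected range from 8000 nM to 50000 nM.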

Compound 3, half-maximal inhibitory concentration: 2300 nM
For compound 3 the middle estimate is 8.7-fold (0.94 log units) above the measured one; the whole stated range lies above it.
By their numbers in this assay, from the lowest: compounds 3 and 1 (each within the scatter of the next); then compound 2.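

In this assay the change to ((tert-butoxycarbonyl)amino)methyl gives a 10-fold lower number from compound 2 to compound 3 (1.02 log units; beyond the scatter), so the weaker result seen earlier with (tert-butoxycarbonyl)amino does not extend to every large group at this position on the aromatic ring. Compared with the methyl group of compound 1, the entering group gives a 2.0-fold lower number from compound 1 to compound 3 (0.29 log units; within the scatter), which shows that this position can carry ((tert-butoxycarbonyl)amino)methyl with no step beyond the scatter. Nothing measured here offers an explanation for the large difference between two such closely related groups.

The compounds shown leave open whether the tert-butoxycarbonyl group itself matters on this chain, which a free aminomethyl group would help to settle. They also leave open whether a longer chain, such as an ethyl link carrying the same protected amine, would behave like compound 3 or like compound 2.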